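The source may hold more compounds than are shown below. What is called first, only, known or untested is meant among the compounds shown, and "the series" means these compounds.

Measured compounds:
compound 1 `C=C1CC[C@H]2C(C)(C)[C@@H](Br)CC[C@]2(C)[C@@H]1Cc1cc(O)c(C=O)cc1O` — 4000 nM
compound 2 `CC(=O)OC[C@H]1[C@@]2(C)CC[C@H](Br)C(C)(C)[C@H]2CC[C@]1(C)O` — > 100000 nM

The study covers two measured compounds. In an ADME assay on MT2 cells (Homo sapiens) for cytotoxicity, read by XTT assay (on this read-out lower numbers stand for higher toxicity in this test and higher numbers for lower toxicity in this test), compound 1 gives 4000 nM, a number within the working range. Compound 2 stands differently: in this assay compound 2 reaches only > 100000 nM, which is a limit of the test and not a number. This is recorded as the limit of > 100000 nM in this assay, at which 1 of the 2 values shown sits, and it means that compound 2 has no fixed value from which to measure, only the edge at which the test stops reporting.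

The unmeasured compound is compound 3 `CC(=O)OC[C@@H]1[C@@]2(C)CC[C@H](Br)C(C)(C)[C@H]2CC[C@]1(C)O`. Set against compound 2, the change is the two compounds have the same atoms and bonds and differ only in configuration as drawn: 1 of 5 stereo elements differ; a stereocentre at a saturated ring carbon is drawn R in compound 2 and S in compound 3. Among the measured compounds shown here, no step between measured compounds is available to calibrate such a change, so the expectation rests on compound 2 alone. For a change that keeps every atom and bond and alters only one stereocentre, no step beyond the usual scatter of this assay is expected, and compound 3 is expected to sit near the same limit as compound 2, so that the expected step of a number no higher from compound 2 to compound 3 (the limit leaves the size open) is essentially flat. Compound 3 is therefore estimated at 100000 nM, with a range from 30000 nM to 300000 nM, most likely reported again as a limit.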

Compound 3, half-maximal cytotoxic concentration: 70000 nM
The estimate for compound 3 lay 1.4-fold (0.15 log units) above the measured number, within the range that was stated.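

In this assay compound 3 gives 70000 nM, a number within the working range, so this pair of mirrored arrangements at one carbon now has a reading on one side where compound 2 alone offered none. Compound 2 stands at > 100000 nM, which is a limit of the assay and not a number. Turning the stereocentre at a saturated ring carbon from R to S gives an at least 1.4-fold lower number from compound 2 to compound 3 (0.15 log units; that floor lies within the scatter), so only a floor for this change is fixed, that floor does not show that the configuration at this carbon matters in this assay, and any real gap could come from this one centre alone: the fact that compounds 2 and 3 differ only in the configuration as drawn

On these data alone, how far compound 2 really lies from compound 3 stays open, since one of the two has only a limit, and so does whether the other stereocentres of the shared core would behave in the same way. Also open, as far as these compounds go, is how this assay would read if a carboxylic acid or an amine took the place of the acetate ester on this core.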